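Swapping Benzoyl for Sulfamoyl on a Stable Core

The source may report more compounds than this note shows. Statements on the series, on what has been measured and on what is new or still open speak of the compounds shown alone.

The measurement in question is an ADME assay on microsomes from liver (Mus musculus) for metabolic stability, read by LC-MS, with NADPH named in the record, with a stated time of 60 min, tested at 1 uM, in the absence of a further agent; a lower number here means that less of the compound is left, a higher number that more of the compound is left. Of the compounds shown here, three that share one core have been measured in this assay so far. Compound 1 `CC(=O)N[C@@H]1CCN(c2cc(C)nn3c(-c4cccc(S(=O)(=O)N(C)C)c4)c(C)nc23)C1` returns a limit of the assay rather than a number, namely > 95%. Compound 2 `CC(=O)N[C@@H]1CCN(c2cc(C)nn3c(-c4ccco4)c(C)nc23)C1` likewise sits at a limit in this assay, giving > 95%. Compound 3 `COc1ccc(-c2c(C)nc3c(N4CC[C@@H](NC(=O)c5ccccc5)C4)cc(C)nn23)cc1OC` also returns only a limit in this assay, > 95%. So compound 3 stands where every measured compound stands, at the limit of > 95% in this assay, at which 3 of the 3 values shown sit. No pair among these three differs in just one place, so no measured step is available to guide an estimate.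

Compound 4 `COc1ccc(-c2c(C)nc3c(N4CC[C@@H](NS(N)(=O)=O)C4)cc(C)nn23)cc1OC` is the next compound to be measured. It differs from compound 3 in one place: sulfamoyl in place of benzoyl on an amine nitrogen. The benzoyl group, a six-membered aromatic ring of carbon only with its carbonyl, gives way to a small sulfamoyl group carrying one hydrogen-bond donor. With all measured values at the limit of > 95% in this assay, at which 3 of the 3 values shown sit, the step of a number at least 3 percentage points lower from compound 3 to compound 4 (that floor lies within the scatter) is expected to be none beyond the scatter. Compound 4 is therefore estimated to give 92% in this assay, with a plausible range from 78% to 99%.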

Compound 4, percent of the compound remaining: > 95%
Compound 4: no number, only a limit (the forecaster's own chance of this, stated with the estimate: 60%); middle value at least 3 percentage points away from the limit.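

In this assay compound 3 and compound 4 each return only a limit of the assay, so no step between them can be read, and the effect of sulfamoyl in place of benzoyl has no readable size: the limit of > 95% in this assay, at which 4 of the 4 values shown sit.

The compounds shown leave open how much these four compounds differ in stability, and whether this swap changes it at all.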